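The source may report more compounds than this note shows. Statements on the series, on what has been measured and on what is new or still open speak of the compounds shown alone.

The compounds share a core whose variations lie at the sulfonyl-bearing aryl and at one carbon of the pyranone-like ring. Compound 1 `COc1ccc(-c2c(I)c(=O)c3c(OC)cc(OC)cc3n2S(=O)(=O)c2ccc(OC)cc2)cc1` carries iodine on the core and a methoxy on the sulfonyl aryl; in a functional assay on SUP-B15 cells (Homo sapiens) for antiproliferative activity, with a stated time of 72 h (a higher number here means that more compound is needed for the effect, a lower number that less compound is needed), compound 1 gives 12300 nM. Compound 2 `COc1ccc(-c2cc(=O)c3c(OC)cc(OC)cc3n2S(=O)(=O)c2ccc(F)cc2)cc1` lacks the iodine and bears fluorine on the sulfonyl aryl. For compound 2 this assay reports only a limit, > 65500 nM. Compound 3 `COc1ccc(-c2cc(=O)c3c(OC)cc(OC)cc3n2S(=O)(=O)c2ccc(C)cc2)cc1` bears a methyl in the same place. For compound 3 this assay again reports only a limit, > 44800 nM. The step that the two limits leave unreadable from compound 2 to compound 3 therefore cannot be sized, since both ends are limits, as shown by the limit of > 44800 nM in this assay, at which 1 of the 3 values shown sits, and (the limit of > 65500 nM in this assay, at which 1 of the 3 values shown sits).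

Compound 4 `COc1ccc(-c2cc(=O)c3c(OC)cc(OC)cc3n2S(=O)(=O)c2ccc(OC)cc2)cc1` is yet to be measured. It differs from compound 3 by methoxy in place of methyl on an aromatic carbon. Going by the values given here, no measured step covers this change directly, and compound 1, which shares the methoxy-bearing sulfonyl aryl, also differs in the iodine. With compound 3 standing at a limit, the expected step that the limit leaves unreadable from compound 3 to compound 4 from compound 3 to compound 4 is unreadable in direction. Compound 4 is expected to give 50000 nM, within 8000 nM to 150000 nM, most likely reported as a limit again.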

Compound 4, half-maximal effective concentration: > 82700 nM
Compound 4: no number, only a limit (the forecaster's own chance of this, stated with the estimate: 70%); at least 1.6-fold (0.21 log units) between middle value and limit.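

In this assay, replacing the 4-methylphenyl with the 4-methoxyphenyl on the sulfonyl group still gives no number, so the steps among compound 2, compound 3 and compound 4 cannot be read, and compound 4 stands at a limit: the limit of > 82700 nM in this assay, at which 1 of the 4 values shown sits. Going by these compounds alone, the methoxy-bearing sulfonyl aryl does, however, link this compound to the iodinated one, giving the first readable step, with hydrogen in place of iodo on an aromatic carbon: an at least 6.7-fold higher number from compound 1 to compound 4 (0.82 log units; beyond the scatter). Among the compounds shown, a number appears only with iodo on the core, and compound 2, compound 3 and compound 4, which all lack it, stand at limits, so this carbon of the core now counts for more in the comparison than the sulfonyl aryl can be shown to.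

From the compounds shown here alone, whether the fluoro, methyl and methoxy groups on the sulfonyl aryl differ at all remains unknown, as does whether they would differ with iodo present on the core. Going by these compounds, it also remains open whether iodo is specifically required at that carbon, or whether bromo or an amine there would likewise give a measurable value.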